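The source may hold more compounds than are shown below. What is called first, only, known or untested is meant among the compounds shown, and "the series" means these compounds.

Measured in a functional assay on the whole organism for inhibition, with Mus musculus as the target, at a dose of 10 mg/kg; a higher number here means more inhibition at the dose given (going by the name of the read-out), a lower number less inhibition:

Compound 1, `O=C1C(COCCCl)=CS(=O)(=O)c2ccccc21`, gives 98.1%.
Compound 2, `O=COCC1=CS(=O)(=O)c2ccccc2C1=O`, gives 91.6%.
Compound 3, `CC(=O)OCC1=CS(=O)(=O)c2ccccc2C1=O`, gives 99.5%.

Compound 3 shows the largest of the three figures, but the step of a number 1.4 percentage points higher from compound 1 to compound 3 (within the scatter) and the step of a number 7.9 percentage points higher from compound 2 to compound 3 (within the scatter) are both within the scatter, so the three compounds cannot be ranked against each other in this assay.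

Compound 4, `O=C(OCC1=CS(=O)(=O)c2ccccc2C1=O)c1ccccc1`, differs from compound 3 by phenyl in place of methyl on a carbonyl carbon. Among the compounds with values here, the one measured step at the same place, a number 7.9 percentage points higher from compound 2 to compound 3 (within the scatter), stayed within the scatter, as did the exchanges on the oxygen on a saturated carbon, a number 6.5 percentage points lower from compound 1 to compound 2 (within the scatter) and a number 1.4 percentage points higher from compound 1 to compound 3 (within the scatter). All three measured compounds sit close together near the top of the scale in this assay. A step of no more than the scatter is therefore expected, a number 3.5 percentage points lower from compound 3 to compound 4 (within the scatter). Compound 4 is estimated at 96%, in a range from 84% to 100%.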

Compound 4, a percentage reported as inhibition, in the whole organism at one dose (the size of the read-out at that dose, not a potency): 0%
Estimate against measurement, compound 4: 96 percentage points above, outside the stated range (below it).
By their numbers in this assay, from the lowest: compound 4; then compounds 2, 1 and 3 (each within the scatter of the next).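

On the carbonyl carbon, hydrogen and methyl gave values within the scatter of each other, so this place looked indifferent to its group, but phenyl brings a number 99.5 percentage points lower from compound 3 to compound 4 (beyond the scatter) and a number 91.6 percentage points lower from compound 2 to compound 4 (beyond the scatter) in this assay. The place therefore does not accept every group, and one exchange here can remove the inhibition altogether. Nothing available explains this loss.

The compounds shown leave open whether the loss belongs to phenyl specifically or would also come with a longer chain such as propyl or a saturated ring such as cyclohexyl. They also leave open how an amine on this carbonyl carbon would behave.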